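Imidazoline ethers: biaryl ring swap at the aromatic carbon

A few compounds are considered here, and "the series" means these few. Any claim that something is new, unique, unknown or untested is made for them only; others in the source may bear on it.

Three members of this series have been run in a functional assay for activation of Alpha-1A adrenergic receptor (Homo sapiens), read by calcium flux; on this read-out higher numbers stand for an effect only at larger amounts of compound and lower numbers for an effect already at smaller amounts. Compound 1 `c1cncc(-c2ccccc2OCC2=NCCN2)c1` gives 2 nM. Compound 2 `c1ccc(-c2ccsc2)c(OCC2=NCCN2)c1` gives 0.251 nM. Compound 3 `c1ccc(-c2ccns2)c(OCC2=NCCN2)c1` gives 5.01 nM, the highest of the three numbers; its nearest neighbour is compound 1 and its furthest is compound 2. The steps run an 8.0-fold lower number from compound 1 to compound 2 (0.90 log units; beyond the scatter), a 2.5-fold higher number from compound 1 to compound 3 (0.40 log units; beyond the scatter) and a 20-fold higher number from compound 2 to compound 3 (1.30 log units; beyond the scatter).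

Compound 4 `Cc1ccoc1-c1ccccc1OCC1=NCCN1` has not yet been measured in this assay. The change from compound 3 is 3-methylfuran-2-yl in place of 1,2-thiazol-5-yl on an aromatic carbon. The step that bears on it most directly is a 20-fold higher number from compound 2 to compound 3 (1.30 log units; beyond the scatter), where a five-membered ring with one hetero atom was replaced by one with two; compound 4 reverses that count, going back to a five-membered ring with a single hetero atom, now bearing a methyl. The step of a 2.5-fold higher number from compound 1 to compound 3 (0.40 log units; beyond the scatter) points the same way, with compound 3 at the weak end of the set in this assay. Among the measured compounds shown here, a furan has not yet been seen, nor has a methyl on the five-membered ring, so the size of the return is uncertain. A modest to large fall in the number is expected, a 5.0-fold lower number from compound 3 to compound 4 (0.70 log units; beyond the scatter). Compound 4 is estimated at 1 nM, within 0.2 nM to 5 nM.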

Compound 4, half-maximal effective concentration: 3.16 nM
Estimate against measurement, compound 4: 3.2-fold (0.50 log units) below, and the stated range covers the measured number.
By their numbers in this assay, from the lowest: compound 2; then compounds 1, 4 and 3 (each within the scatter of the next, the first and the last beyond it).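

In this assay, going back to a five-membered aromatic ring with 1 hetero atom does not by itself restore the low number of compound 2 (a 13-fold higher number from compound 2 to compound 4 (1.10 log units; beyond the scatter)), so the hetero atom count alone does not set the number at this aromatic carbon. The 3-methylfuran-2-yl group instead falls in with the other two rings, with both remaining steps inside the scatter (a 1.6-fold lower number from compound 3 to compound 4 (0.20 log units; within the scatter); a 1.6-fold higher number from compound 1 to compound 4 (0.20 log units; within the scatter)), and among the four compounds only thiophen-3-yl stands apart from the rest. No measurement bears on why these rings differ, and no cause can be given for this result.

The step from thiophen-3-yl to 3-methylfuran-2-yl changes the hetero atom, the point of attachment and the methyl together, so the share of each in the large step remains unresolved. From the compounds shown here alone, whether a furan-3-yl, an unsubstituted furan-2-yl or a 3-methylthiophen-2-yl would sit with compound 2 or with compound 4 stays open, as does the effect of an amine or a longer alkyl chain on the five-membered ring.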